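Methyl on the amine nitrogen: a second test

The compounds below may be only part of what the source reports. "The series", "measured", "known", "first", "only" and "open" are said of these compounds alone.

Compound 1 `COc1ccc(C(=O)c2ccc3c(c2)C=CC(C)(C)O3)c(NC(=O)CN)c1` gives 490 nM in a functional assay on HCT-8 cells (Homo sapiens) for antiproliferative activity, read by MTT assay, with a stated time of 48 h; a lower number here means a stronger inhibitor, a higher number a weaker inhibitor.
Compound 2 `CNCC(=O)Nc1cc(OC)ccc1C(=O)c1ccc2c(c1)C=CC(C)(C)O2` gives 1010 nM in this assay.
Compound 3 `C=C(c1ccc(OC)cc1NC(=O)CN)c1ccc(OC)c2c1C=CC(C)(C)O2` gives 520 nM in this assay.

The three measured compounds fall close together. Compound 1 and compound 3 differ in more than one place, and the difference between the two cores is not broken down here; their values, however, lie within the usual scatter of each other, so no order can be read between them.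

Within the data shown here, the one counted change among the measured compounds is the step (methyl in place of hydrogen on an amine nitrogen). It brought a 2.1-fold higher number from compound 1 to compound 2 (0.31 log units; beyond the scatter), a modest step that nonetheless lies beyond the scatter.

Compound 4 `C=C(c1ccc(OC)cc1NC(=O)CNC)c1ccc(OC)c2c1C=CC(C)(C)O2` has not yet been measured. It differs from compound 3 by methyl in place of hydrogen on an amine nitrogen, which is the same change as that from compound 1 to compound 2: the place, an amine nitrogen whose other neighbours are a saturated chain carbon, is described in identical words in both pairs. The remaining question is whether the weakening seen on the core of compound 1 carries over to the core of compound 3.

Among the measured compounds shown here, with only one earlier instance to go on, the expectation for compound 4 rests on that instance: the step of a 1.9-fold higher number from compound 3 to compound 4 (0.28 log units; within the scatter) is expected to be of about the size of a 2.1-fold higher number from compound 1 to compound 2 (0.31 log units; beyond the scatter). Compound 4 is therefore estimated at 1000 nM, with a plausible range from 500 nM to 2200 nM.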

Compound 4, half-maximal inhibitory concentration: 980 nM
Beside the measured number, compound 4's estimate is 1.0-fold (0.01 log units) above it; measured number inside the range.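

In this assay, methyl in place of hydrogen on an amine nitrogen gave a 1.9-fold higher number from compound 3 to compound 4 (0.28 log units; within the scatter), so on the core of compound 3, taken alone, the step cannot be told apart from the usual scatter. Set beside the earlier instance of the same change, the new step does not differ from it: the same change on two cores in this assay, a 2.1-fold higher number (0.31 log units; beyond the scatter) from compound 1 to compound 2 and a 1.9-fold higher number (0.28 log units; within the scatter) from compound 3 to compound 4, 1.1-fold (0.04 log units) apart, within the scatter of two such steps. Among these compounds, this shows that in these two pairs the change carried from one core to the other with a step of matching size, but it rests on only two pairs, one of whose steps lies within the scatter, so it does not establish a rule for any further core.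

The compounds shown leave open how an ethyl group, a second methyl on the same nitrogen, or an acetyl group in place of the methyl would fare on either core, and whether such groups would also carry from one core to the other. They also leave open whether a longer chain in place of the aminomethyl group, or a carboxylic acid in place of the amine, would keep steps of matching size on the two cores.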